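The source may report more compounds than this note shows. Statements on the series, on what has been measured and on what is new or still open speak of the compounds shown alone.

Measured so far in a functional assay on A-431 cells (Homo sapiens) for cytotoxicity, read by MTT assay, with a stated time of 72 h; on this read-out higher numbers stand for weaker inhibition and lower numbers for stronger inhibition:
compound 1 `Cc1ccnc(/C(N)=N/NC(=S)N2CCOCC2)c1`, 6800 nM
compound 2 `Cc1cccc(/C(N)=N/NC(=S)N2CCSCC2)n1`, 2600 nM
compound 3 `Cc1ccnc(/C(N)=N/NC(=S)N2CCSCC2)c1`, 7200 nM

Compound 2 gives the lowest of the three numbers, and both compound 1 and compound 3 stand beyond the scatter from it. Compound 3 and compound 1 differ in one place, (morpholin-4-yl in place of thiomorpholin-4-yl on a thiocarbonyl carbon), and this gave a 1.1-fold lower number from compound 3 to compound 1 (0.02 log units; within the scatter). The difference between the core of compound 2 and the core of compound 3 is not broken down here.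

Compound 4 `Cc1cccc(/C(N)=N/NC(=S)N2CCOCC2)n1` is not yet measured in this assay. From compound 2 it differs by morpholin-4-yl in place of thiomorpholin-4-yl on a thiocarbonyl carbon, the same change as from compound 3 to compound 1. Because that earlier step was a 1.1-fold lower number from compound 3 to compound 1 (0.02 log units; within the scatter), the step from compound 2 to compound 4 is expected to be small, about a 1.1-fold lower number from compound 2 to compound 4 (0.03 log units; within the scatter). Compound 4 is therefore estimated at 2400 nM, with a range of 1200 nM to 5000 nM.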

Compound 4, half-maximal inhibitory concentration: 4300 nM
Estimate against measurement, compound 4: 1.8-fold (0.25 log units) below; the range from low to high includes it.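

In this assay, replacing thiomorpholin-4-yl with morpholin-4-yl on a thiocarbonyl carbon gives a 1.7-fold higher number from compound 2 to compound 4 (0.22 log units; within the scatter), and the comparison across cores reads: the same change on two cores in this assay, a 1.1-fold lower number (0.02 log units; within the scatter) from compound 3 to compound 1 and a 1.7-fold higher number (0.22 log units; within the scatter) from compound 2 to compound 4, 1.8-fold (0.24 log units) apart, within the scatter of two such steps. Going by these compounds alone, on these two cores, the change therefore carries over with no step or gap beyond the scatter. Within the data shown here, this does not show that the two groups are interchangeable on other cores, since only two pairs are available and neither step separates its two compounds.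

The compounds shown leave open how a ring carrying an amine, such as piperazin-1-yl, or an all-carbon ring, such as piperidin-1-yl, would behave on a thiocarbonyl carbon. They also leave open whether an ethyl group or a longer chain in place of the methyl group would alter the picture.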